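The source may hold more compounds than are shown below. What is called first, only, known or untested is meant among the compounds shown, and "the series" means these compounds.

In a functional assay on the whole organism (strain CD1) with Mus musculus as the target, in the maximal electroshock model, with a stated time of 0.5 h (on this read-out lower numbers stand for an effect already at smaller amounts and higher numbers for an effect only at larger amounts of compound), compound 1 `CC1CC(=O)N(CC(=O)N2CCN(c3ccccc3)CC2)C1=O` gives 300 mg/kg, and compound 2 `Cc1cccc(N2CCN(C(=O)CN3C(=O)CC(C)C3=O)CC2)c1` gives 300 mg/kg; the two stand level at the digits shown, together the highest of the three numbers. Compound 3 `CCC1(C)CC(=O)N(CC(=O)N2CCN(c3ccccc3C)CC2)C1=O` gives 100 mg/kg, a lower number than compound 2, beyond the scatter. For the measured compounds named here, the only step between measured compounds that differ in one place, no change at the digits printed from compound 1 to compound 2 (within the scatter), adds a methyl in place of hydrogen on an aromatic carbon and leaves the number where it was.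

Compound 4 `Cc1ccccc1N1CCN(C(=O)CN2C(=O)CC(C)C2=O)CC1` differs from compound 2 by 2-methylphenyl in place of 3-methylphenyl on an amine nitrogen in a ring. Going by the values given here, no measured step moves a methyl around the same ring, so the step from compound 1 to compound 2 is the closest guide, and it showed no change; the lower number of compound 3 belongs to a compound with a different core and cannot be read as a step. For compound 4 a value near that of compound 2 is therefore expected, with the step of no change at the digits printed from compound 2 to compound 4 (within the scatter) estimated to stay within the scatter, giving an estimate of 300 mg/kg with a range from 100 mg/kg to 600 mg/kg.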

Compound 4, minimum effective dose: 300 mg/kg
Estimate against measurement, compound 4: no gap at the digits printed; low and high end bracket the measured number.
By their numbers in this assay, from the lowest: compound 3; then compounds 1, 2 and 4 (each within the scatter of the next).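

In this assay, exchanging one methyl position for the other gives no change at the digits printed from compound 2 to compound 4 (within the scatter), and adding a methyl to the aromatic ring gives no change at the digits printed from compound 1 to compound 4 (within the scatter), so neither of these changes on the aromatic ring moves the number. The new compound also gives a first step at a different place, where hydrogen in place of ethyl on a saturated ring carbon gives a 3.0-fold higher number from compound 3 to compound 4 (0.48 log units; beyond the scatter); among these four compounds, this is the only step that goes beyond the scatter.

From the compounds shown here alone, it remains open whether a group other than methyl on the aromatic ring, such as a chlorine atom or a carboxylic acid, would shift the number. Going by these compounds, it is equally open whether a longer chain than ethyl on the saturated ring carbon, such as propyl, would lower it further, and no measurement here accounts for the effect of the ethyl group.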